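The source may report more compounds than this note shows. Statements on the series, on what has been measured and on what is new or still open speak of the compounds shown alone.

Working notes on the series.

Two compounds of this set have a number in a functional assay for inhibition, with Homo sapiens as the target (a higher number here means a weaker inhibitor, a lower number a stronger inhibitor), so far. Compound 1, `Cc1cc(C)cc(Nc2nccc(-c3cc(C)oc3C)n2)c1`, gives 4100 nM in this assay. Compound 2, `Cc1cccc(Nc2nccc(-c3ccco3)n2)c1`, gives 2100 nM in this assay. On these two numbers compound 2 has the lower one, but the gap to compound 1 lies within the scatter of repeated measurements, so the two are not separated by the data.

Compound 3, `Cc1cc(C)cc(Nc2nccc(-c3ccco3)n2)c1`, is the next member and has not yet been measured. It differs from compound 2 in one place: methyl in place of hydrogen on an aromatic carbon.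

Within the data shown here, no pair of measured compounds shows this change on its own, so the size of the step is open. Among the measured compounds shown here, the one comparison available, compound 1 against compound 2, mixes this change with a second one on the other ring and falls within the scatter anyway. For a single methyl entering, the expectation is a step no larger than the scatter, with no clear direction. The expected step from compound 2 to compound 3 in this assay is a 1.3-fold higher number from compound 2 to compound 3 (0.12 log units; within the scatter). For compound 3 the estimate in this assay is 2800 nM, with a range from 1200 nM to 6500 nM.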

Compound 3, half-maximal inhibitory concentration: 700 nM
The estimate for compound 3 lay 4.0-fold (0.60 log units) above the measured number, and the stated range ends above it.
By their numbers in this assay, from the lowest: compound 3; then compounds 2 and 1 (each within the scatter of the next).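

In this assay, this position now has a step of its own: methyl in place of hydrogen on an aromatic carbon of the six-membered aromatic ring of carbon only, meta to a large group and meta to a methyl group, gives a 3.0-fold lower number from compound 2 to compound 3 (0.48 log units; beyond the scatter), so a single methyl here is not a neutral change. The other ring also carries a step when the first ring is held constant: furan-2-yl in place of 2,5-dimethylfuran-3-yl gives a 5.9-fold lower number from compound 1 to compound 3 (0.77 log units; beyond the scatter). Both single changes end at compound 3, which has the lowest number of the three in this set, and no measured property bears on why either step occurs.

The compounds shown hold only hydrogen or methyl at this position, so it remains open whether an ethyl group, a methoxy group, an amine or a carboxylic acid there would extend the step or reverse it. On these data alone, the 2,5-dimethylfuran-3-yl group appears only in compound 1, so it also remains open whether the methyl step carries over to compounds with that group.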